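This account rests on a few compounds, and the source may have more. Where it says the series, first, only, none or still open, it means among the compounds named here.

Among the compounds with values here, compound 2 `O=C(Nc1ccc(C(F)(F)F)cc1)N1CCOC2(CCN(C(=O)c3ccccc3)CC2)C1` has the smallest of the three numbers so far in an ADME assay on stomach for solubility, in simulated gastric fluid (a lower number here means a less soluble compound, a higher number a more soluble compound), giving 62 ug/mL, although the gaps to its neighbours lie within the scatter. Compound 1 `CC(C)(C)C(=O)N1CCC2(CC1)CN(C(=O)Nc1ccc(C(F)(F)F)cc1)CCO2` gives 76 ug/mL in this assay, and compound 3 `Cc1cc(C(=O)N2CCC3(CC2)CN(C(=O)Nc2ccc(OC(F)(F)F)cc2)CCO3)no1` gives 84 ug/mL. Within the data shown here, the one measured step among them, a 1.2-fold lower number from compound 1 to compound 2 (0.09 log units; within the scatter), shows that swapping the group on the carbonyl carbon left the number essentially unchanged. Compound 4 `O=C(Nc1ccc(C(F)(F)F)cc1)N1CCOC2(CCN(C(=O)c3ccccn3)CC2)C1` differs from compound 2 by pyridin-2-yl in place of phenyl on a carbonyl carbon. No measured step exchanges a ring of carbon only for a ring with one hetero atom, so nothing shown bears directly on this change; the step from compound 1 to compound 2 only indicates that this carbonyl position has tolerated a change without moving the number beyond the scatter. On that basis the expected step in this assay, a 1.3-fold higher number from compound 2 to compound 4 (0.11 log units; within the scatter), is small and of uncertain direction. Compound 4 is therefore estimated at 80 ug/mL, with a range from 40 ug/mL to 160 ug/mL.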

Compound 4, solubility: 85 ug/mL
Estimate against measurement, compound 4: 1.1-fold (0.03 log units) below; low and high end bracket the measured number.
By their numbers in this assay, from the lowest: compounds 2, 1, 3 and 4 (each within the scatter of the next).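

In this assay, within the data shown here, the step of a 1.4-fold higher number from compound 2 to compound 4 (0.14 log units; within the scatter) is the first exchange at this position of a ring of carbon only for a ring with one hetero atom, and it stays inside the scatter. The step of a 1.1-fold higher number from compound 1 to compound 4 (0.05 log units; within the scatter) is likewise inside the scatter, so this read-out does not separate tert-butyl, phenyl and pyridin-2-yl on a carbonyl carbon whose other neighbour is an amide-type nitrogen in a ring. Nothing available explains this result.

The compounds shown leave open whether a carboxylic acid or an aminomethyl group on the ring at this position would give a step beyond the scatter. They also leave open whether the exchange of phenyl for pyridin-2-yl would read the same with trifluoromethoxy in place of trifluoromethyl on the urea's aromatic ring.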